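The source may report more compounds than this note shows. Statements on the series, on what has been measured and on what is new or still open speak of the compounds shown alone.

Working notes on the series. Compound 2, `COc1ccc(S(=O)(=O)c2cnc3cc(Cl)ccc3c2N2CCC(C)CC2)cc1OC`, gives 93% in an assay on isolated protein for displacement of a labelled ligand from metabotropic glutamate receptor 5 (Homo sapiens), with a stated time of 60 min, tested at 1 uM; on this read-out lower numbers stand for less inhibition and higher numbers for more inhibition at the one concentration tested (going by the name of the read-out). Compound 1, `CC1CCN(c2c(S(=O)(=O)c3cccc(C#N)c3)cnc3cc(Cl)ccc23)CC1`, gives 94% in this assay, and compound 3, `CC1CCN(c2c(S(=O)(=O)c3ccccc3)cnc3cc(F)ccc23)CC1`, gives 87% in this assay; compound 2 sits between these two numbers, and all three lie within the usual scatter of one another. Compound 4, `CC1CCN(c2c(S(=O)(=O)c3ccc(C#N)cc3)cnc3cc(Cl)ccc23)CC1`, is not yet measured in this assay. The change from compound 2 to compound 4 is 4-cyanophenyl in place of 3,4-dimethoxyphenyl on a sulfonyl sulfur. Among the measured compounds shown here, the one measured step that bears on this is the swap of aryl groups on the sulfonyl sulfur, a number 1 percentage points lower from compound 1 to compound 2 (within the scatter), which shows that exchanging 3-cyanophenyl for 3,4-dimethoxyphenyl at this place leaves the read-out essentially unchanged. Going back to a cyanophenyl group, now 4-cyanophenyl, is therefore expected to give no step beyond the scatter in this assay, so no change at the digits printed from compound 2 to compound 4 (within the scatter) is the expected step. Compound 4 is estimated at 93% in this assay, in the range 85% to 98%.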

Compound 4, a percentage reported as inhibition, at one concentration (the size of the read-out at that concentration, not a potency): 70%
Compound 4: middle estimate off by 23 percentage points, on the high side; the whole stated range lies above it.
By their numbers in this assay, from the lowest: compound 4; then compounds 3, 2 and 1 (each within the scatter of the next).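

In this assay a change of the aryl group on the sulfonyl sulfur can move the number further than the earlier pair alone indicated: 4-cyanophenyl in place of 3,4-dimethoxyphenyl gives a number 23 percentage points lower from compound 2 to compound 4 (beyond the scatter). The place of the nitrile on that ring also counts, since 4-cyanophenyl in place of 3-cyanophenyl gives a number 24 percentage points lower from compound 1 to compound 4 (beyond the scatter), so two groups with the same atoms are not interchangeable here. No measurement on these compounds accounts for this difference.

Compound 3 differs from compound 4 in more than one place, so the contribution of the nitrile itself cannot be read from that pair. Going by these compounds, it remains open whether an amine or a carboxylic acid in place of the nitrile of 4-cyanophenyl would keep the lower number of compound 4 or return to the level of compound 1.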